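This account rests on a few compounds, and the source may have more. Where it says the series, first, only, none or still open, it means among the compounds named here.

Compound 1 `Cc1ccc(Nc2nc(N)nc(COc3ccc4c(c3)CCC(C)(C)O4)n2)cc1` belongs to this series, and in an assay on COS-7 cells for agonist activity at Free fatty acid receptor 1 (Homo sapiens), read by scintillation counting and inositol phosphate accumulation, with a stated time of 90 min (on this read-out lower numbers stand for an effect already at smaller amounts and higher numbers for an effect only at larger amounts of compound), compound 1 gives "not determined" (no result reported), so no number stands against it. Compound 2 `Cc1ccc(Nc2nc(N)nc(COc3cccc(N4CCCC4=O)c3)n2)cc1Cl` and compound 3 `Cc1ccc(Nc2nc(N)nc(COc3cc(N4CCCC4=O)cc(C(F)(F)F)c3)n2)cc1Cl` share the same core and differ at a single aromatic carbon, where compound 3 carries a trifluoromethyl group. In this assay compound 2 gives 820 nM, and compound 3 gives 3190 nM, the highest of the two numbers at hand; the change between them amounts to a 3.9-fold higher number from compound 2 to compound 3 (0.59 log units; beyond the scatter). Compound 4 `Cc1ccc(Nc2nc(N)nc(COc3cc(C#N)cc(N4CCCC4=O)c3)n2)cc1Cl` arises from compound 3 by one change: cyano in place of trifluoromethyl on an aromatic carbon. Among the compounds with values here, only the step from compound 2 to compound 3 touches this position, and it shows that placing a trifluoromethyl there raised the number beyond the scatter. Since cyano brings fewer heavy atoms than the trifluoromethyl it replaces, the number for compound 4 is expected to sit between the two measured values, as a step of a 2.1-fold lower number from compound 3 to compound 4 (0.33 log units; beyond the scatter). The estimate for compound 4 is therefore 1500 nM, with a range from 600 nM to 4000 nM.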

Compound 4, half-maximal effective concentration: 4170 nM
Compound 4: middle estimate off by 2.8-fold (0.44 log units), on the low side; measured number outside the range, above it.
By their numbers in this assay, from the lowest: compound 2; then compounds 3 and 4 (each within the scatter of the next).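

Replacing trifluoromethyl with cyano, a group with fewer heavy atoms, does not bring the number back towards that of the unsubstituted compound: a 1.3-fold higher number from compound 3 to compound 4 (0.12 log units; within the scatter) in this assay, so these two groups cannot be told apart here. The comparison with hydrogen gives a 5.1-fold higher number from compound 2 to compound 4 (0.71 log units; beyond the scatter), which shows that the rise at this aromatic carbon is not confined to trifluoromethyl, as two different groups now both give higher numbers than hydrogen. Nothing available explains why these two groups give such similar results.

Still open is whether any group at this position can match or improve on hydrogen, since only hydrogen, trifluoromethyl and cyano are shown there. A single fluorine, a methoxy group, an amine or a carboxylic acid at this carbon could answer that.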